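A few compounds are considered here, and "the series" means these few. Any claim that something is new, unique, unknown or untested is made for them only; others in the source may bear on it.

In a toxicity assay on L3.6pl cells (Homo sapiens) for inhibition, read by ATP content, with a stated time of 72 h (a higher number here means a weaker inhibitor, a lower number a stronger inhibitor), compound 3 `COc1ccccc1C(=O)Nc1ccc(N2CCN(Cc3ccccc3)CC2)cc1C(=O)O` gives > 10000 nM. That value is a limit of the assay and not a number. Two relatives with a substituted phenyl group on the amine nitrogen in a ring do give numbers: compound 1 `COc1ccccc1C(=O)Nc1ccc(N2CCN(c3cc(Cl)ccc3C)CC2)cc1C(=O)O` reads 29100 nM and compound 2 `COc1ccccc1C(=O)Nc1ccc(N2CCN(c3cccc(C)c3C)CC2)cc1C(=O)O` reads 22900 nM. These two are separated by a 1.3-fold lower number from compound 1 to compound 2 (0.10 log units; within the scatter).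

Compound 4 `COc1ccccc1C(=O)Nc1ccc(N2CCN(CCCc3ccccc3)CC2)cc1C(=O)O` alters only the chain on that nitrogen: phenethyl in place of phenyl on a saturated chain carbon bound to an amine nitrogen in a ring. Read one bond further out, benzyl gives way to 3-phenylpropyl. Within the data shown here, no measured step covers this change directly. The nearest are a step that the limit leaves unreadable from compound 1 to compound 3 and a step that the limit leaves unreadable from compound 2 to compound 3, so neither offers a size to carry over. Among the measured compounds shown here, the one readable step, a 1.3-fold lower number from compound 1 to compound 2 (0.10 log units; within the scatter), concerns the substituents on the phenyl group, not the chain. No firm direction can therefore be argued, and compound 4 is expected to stay in the same weak region as compound 2 at 22900 nM. A report as a limit alone is also quite possible. Estimated on this basis, the expected step is a step that the limit leaves unreadable from compound 3 to compound 4. For compound 4 the estimated value is 18000 nM, with an expected range from 7000 nM to 40000 nM.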

Compound 4, half-maximal inhibitory concentration: > 10000 nM
Compound 4 was reported as a limit (the forecaster's own chance of this, stated with the estimate: 45%); the middle value lies beyond the limit too.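

In this assay, among these compounds, compound 4 gives > 10000 nM, a limit and not a number, so no step from compound 1, compound 2 or compound 3 to compound 4 can be read: the limit of > 10000 nM in this assay, at which 2 of the 4 values shown sit. The compounds shown leave open how the chains of compound 3 and compound 4 compare with each other, or with the substituted phenyl groups of compound 1 and compound 2.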